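Inverting one stereocentre in a low-inhibition series

This account rests on a few compounds, and the source may have more. Where it says the series, first, only, none or still open, it means among the compounds named here.

Measured compounds:
Compound 1, `CCOC(=O)/C=C\NC(=O)[C@H](O)C(C)(C)CO`, gives 1% in an ADME assay on WI-38 cells (Homo sapiens) for inhibition, read by CellTiter-Glo, with a stated time of 48 h, tested at 100 uM; a higher number here means more inhibition at the concentration tested (going by the name of the read-out), a lower number less inhibition.
Compound 2, `CC(C)(C)OC(=O)/C=C/NC(=O)[C@H](O)C(C)(C)CO`, gives 0% in this assay.
Compound 3, `CC(C)(CO)[C@@H](O)C(=O)N/C=C\C(=O)OCc1ccccc1`, gives 4% in this assay.

Compound 2 sits at the foot of these three numbers, but the gap to compound 1 at 1% and the gap to compound 3 at 4% both lie within the usual scatter, so the three compounds cannot be told apart on this read-out. For the measured compounds named here, the only measured step, a number 3 percentage points higher from compound 1 to compound 3 (within the scatter), concerns the ester portion and stays within the scatter as well.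

Compound 4, `CC(C)(C)OC(=O)/C=C/NC(=O)[C@@H](O)C(C)(C)CO`, has not yet been measured in this assay. It differs from compound 2 as follows: the two compounds have the same atoms and bonds and differ only in configuration as drawn: 1 of 2 stereo elements differ; a stereocentre at a saturated chain carbon is drawn R in compound 2 and S in compound 4. Going by the values given here, no measured pair in this set shows a change of configuration, so there is no step that bears directly on this one. Among the compounds with values here, all three measured compounds inhibit at close to nothing, and the one step that exists is flat.

Compound 4 is therefore expected to show essentially no inhibition beyond the scatter, an estimated step of a number 1 percentage points higher from compound 2 to compound 4 (within the scatter). The estimate for compound 4 is 1%, in a range from -8% to 10%.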

Compound 4, a percentage reported as inhibition, at one concentration (the size of the read-out at that concentration, not a potency): 14%
Estimate against measurement, compound 4: 13 percentage points below, outside the stated range (above it).
By their numbers in this assay, from the lowest: compounds 2, 1, 3 and 4 (each within the scatter of the next, the first and the last beyond it).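

In this assay, for the compounds shown here, inverting the stereocentre at the saturated chain carbon, drawn R in compound 2 and S in compound 4, gives a number 14 percentage points higher from compound 2 to compound 4 (beyond the scatter), the first step in this set to clear the scatter. The earlier compounds shown here offered only a flat step in the ester portion, whereas this pair shows that the number can respond to the configuration at this one carbon, even with the atoms and bonds left as they are. The rise can be assigned to the stereocentre alone, because nothing else separates the pair: the fact that compounds 2 and 4 differ only in the configuration as drawn

The compounds shown leave open whether the same inversion would give a step of similar size on the ester of compound 1 or compound 3, whose alkene is also drawn differently from that of compound 2, since this is the only pair that differs in configuration. They also leave open whether the step would hold if a carboxylic acid or an amine took the place of the ester, and how the inhibition would change at concentrations other than the single one tested.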